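The source may report more compounds than this note shows. Statements on the series, on what has been measured and on what is new or still open speak of the compounds shown alone.

Values measured in a physicochemical assay for lipophilicity, read by HPLC, at pH 7.5; on this read-out lower numbers stand for lower lipophilicity and higher numbers for higher lipophilicity:
- compound 1 `CCOc1ccccc1-c1ccc(-c2nc3cnccc3cc2C#N)cc1`: 3.8
- compound 2 `CCOc1ccccc1-c1ccc(-c2nc3cnccc3c(C[C@H](C)C(=O)O)c2C#N)cc1`: 2.2
- compound 3 `CCOc1ccccc1-c1ccc(-c2nc3cnccc3c(N)c2C#N)cc1`: 3

Compound 3 stands in the middle of these numbers, with both gaps beyond the usual scatter. Compound 4 `CCOc1ccccc1-c1ccc(-c2nc3cnccc3c(C[C@H](C)C(N)=O)c2C#N)cc1` differs from it in one place: 2-carbamoylpropyl in place of amino on an aromatic carbon.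

Among the measured compounds shown here, three measured steps bear on this: a number 0.80 log units lower from compound 1 to compound 3 (beyond the scatter) for amino, a number 1.60 log units lower from compound 1 to compound 2 (beyond the scatter) for 2-carboxypropyl, and a number 0.80 log units higher from compound 2 to compound 3 (beyond the scatter) on exchanging one group for the other. For the measured compounds named here, the 2-carboxypropyl group is the closest measured chain, but no measured compound carries 2-carbamoylpropyl, so this guide is loose.

The expected step is small and upward, possibly within the scatter: a number 0.20 log units higher from compound 3 to compound 4 (within the scatter). The estimate for compound 4 is 3.2, with an expected range from 2.7 to 3.7.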

Compound 4, distribution coefficient: 3
For compound 4 the middle estimate is 0.20 log units above the measured one; the measured number falls inside the stated range.
By their numbers in this assay, from the lowest: compound 2; then compounds 3 and 4 (each within the scatter of the next); then compound 1.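

In this assay the position ortho to a cyano group gives no change at the digits printed from compound 3 to compound 4 (within the scatter) when 2-carbamoylpropyl, with its 6 heavy atoms, replaces the single-atom amino group. Amino in place of hydroxy on the carbonyl carbon gives a number 0.80 log units higher from compound 2 to compound 4 (beyond the scatter) for the same chain, so the end of the chain matters here, not just its presence. Set against hydrogen, the chain gives a number 0.80 log units lower from compound 1 to compound 4 (beyond the scatter) on this read-out.

From the compounds shown here alone, a shorter chain ending in an amine, or a longer one ending in the same amide, remains open at this position. No measured evidence explains these numbers.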